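A few compounds are considered here, and "the series" means these few. Any claim that something is new, unique, unknown or untested is made for them only; others in the source may bear on it.

Series on a shared core carrying a 4-cyanobutoxy chain. Compound 1 `CCCc1cc(C(C)=O)ccc1OCCCCC#N` in an assay on isolated protein for binding affinity to leukotriene B4 receptor 1 (Homo sapiens), tested at 1 uM (on this read-out higher numbers stand for more inhibition at the one concentration tested (going by the name of the read-out) and lower numbers for less inhibition), gives 19%. Compound 2 `CCCc1cc(C(C)=O)c(O)c(CCC)c1OCCCCC#N` in this assay gives 0%, the lowest of the two numbers, with compound 1 standing higher by a gap beyond the scatter. Compound 3 `CCCc1c(OCCCCC#N)ccc(C(C)=O)c1O` is not yet measured; it differs from compound 2 by hydrogen in place of propyl on an aromatic carbon. Among the compounds with values here, no step between measured compounds is available, so any expectation rests on the two values alone. The step of a number 8 percentage points higher from compound 2 to compound 3 (within the scatter) is expected to be small and upward, not clearly beyond the scatter. Compound 3 is estimated at 8% with a range of 0% to 25%.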

Compound 3, a percentage reported as inhibition, at one concentration (the size of the read-out at that concentration, not a potency): 9%
The estimate for compound 3 lay 1 percentage points below the measured number; the range from low to high includes it.
By their numbers in this assay, from the lowest: compounds 2, 3 and 1 (each within the scatter of the next, the first and the last beyond it).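

In this assay hydrogen in place of propyl, on the aromatic carbon ortho to a 4-cyanobutoxy group, gives a number 9 percentage points higher from compound 2 to compound 3 (within the scatter) and so shows no readable effect of propyl at this position. Hydroxy in place of hydrogen gives a number 10 percentage points lower from compound 1 to compound 3 (within the scatter) and is likewise not readable alone, although compound 1 and compound 2 stand apart beyond the scatter. Nothing measured here bears on the cause of either step.

From the compounds shown here alone, whether a longer chain at this position, or a carboxylic acid in place of the nitrile, would move inhibition beyond the scatter remains open.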